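The source may hold more compounds than are shown below. What is called first, only, known or untested is meant among the compounds shown, and "the series" means these compounds.

In a functional assay on A549 cells (Homo sapiens) for antiproliferative activity, read by sulforhodamine B assay, with a stated time of 48 h (a lower number here means a stronger inhibitor, a higher number a weaker inhibitor), compound 1 (`COc1ccc(C[C@@H](O)/C=C/C=C/C(=O)N2CCN(c3ccccc3)CC2)cc1OC`) gives 14200 nM and compound 2 (`COc1ccc(C[C@@H](O)/C=C/C=C/C(=O)N2CCN(c3ccccn3)CC2)cc1OC`) gives 8130 nM. For the measured compounds named here, these are the only two numbers available, and they lie within the scatter of each other, so the data do not separate compound 2 from compound 1.

Compound 3 (`COc1ccc(C[C@@H](O)/C=C/C=C/C(=O)N2CCN(c3ncccn3)CC2)cc1OC`) keeps the core of compound 2 and differs only in the aromatic group on an amine nitrogen in a ring, where pyrimidin-2-yl stands in place of pyridin-2-yl: pyrimidin-2-yl in place of pyridin-2-yl on an amine nitrogen in a ring.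

Going by the values given here, one measured step bears on this change. Pyridin-2-yl in place of phenyl at that same nitrogen gave a 1.7-fold lower number from compound 1 to compound 2 (0.24 log units; within the scatter), a step within the scatter. That single small step is thin evidence, but it offers no reason to look for a large shift, so no step beyond the scatter is expected in this assay, and no direction is favoured. The estimated step is a 1.0-fold lower number from compound 2 to compound 3 (0.01 log units; within the scatter). Compound 3 is expected to give about 8000 nM, with an estimated range from 3000 nM to 20000 nM.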

Compound 3, half-maximal inhibitory concentration: 9920 nM
Beside the measured number, compound 3's estimate is 1.2-fold (0.09 log units) below it; low and high end bracket the measured number.
By their numbers in this assay, from the lowest: compounds 2, 3 and 1 (each within the scatter of the next).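

In this assay the further change from one hetero atom to two hetero atoms in the aromatic ring on this nitrogen stays within the scatter (a 1.2-fold higher number from compound 2 to compound 3 (0.09 log units; within the scatter)), and so does the direct comparison with phenyl (a 1.4-fold lower number from compound 1 to compound 3 (0.16 log units; within the scatter)). The earlier pair covered only a single replacement, whereas phenyl, pyridin-2-yl and pyrimidin-2-yl now form a set of three six-membered aromatic rings on an amine nitrogen in a ring that this assay does not separate, and no trend with the number of hetero atoms can be read from them. No other measurement is available to account for this result.

On these data alone, all three compounds carry an unsubstituted six-membered aromatic ring at this nitrogen, so it remains open whether a different kind of group there, such as a benzyl group, a simple methyl group or a phenyl ring bearing a chlorine atom or a carboxylic acid, would give a step beyond the scatter. As far as these compounds go, the shared core is also unchanged across these compounds, so what the hydroxyl group, the two methoxy groups or the chain contribute to the numbers remains unknown.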